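Notes on compound 4: quinolin-3-yl replaces 2,6-dichloropyridin-4-yl

A few compounds are considered here, and "the series" means these few. Any claim that something is new, unique, unknown or untested is made for them only; others in the source may bear on it.

Of the compounds shown here, three have been measured in a functional assay on Jurkat cells for inhibition of nuclear factor NF-kappa-B complex (Homo sapiens); a higher number here means a weaker inhibitor, a lower number a stronger inhibitor. Compound 1 `CCOC(=O)c1cnc(C(F)(F)F)nc1NN1C(=O)C=C(C)C1=O` gives 1000 nM, compound 2 `CCOC(=O)c1cnc(C(C)(C)C)nc1NN1C(=O)C=C(C)C1=O` gives 1000 nM, and compound 3 `CCOC(=O)c1cnc(-c2cc(Cl)nc(Cl)c2)nc1NN1C(=O)C=C(C)C1=O` gives 2000 nM. Compound 3 carries the highest number of the three, but the steps to it are a 2.0-fold higher number from compound 1 to compound 3 (0.30 log units; within the scatter) and a 2.0-fold higher number from compound 2 to compound 3 (0.30 log units; within the scatter), so all three sit at one level within the scatter; the comparison no change at the digits printed from compound 1 to compound 2 (within the scatter) fits the same picture.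

Compound 4 `CCOC(=O)c1cnc(-c2cnc3ccccc3c2)nc1NN1C(=O)C=C(C)C1=O` has not been measured. The change is quinolin-3-yl in place of 2,6-dichloropyridin-4-yl on an aromatic carbon. Among the compounds with values here, the steps that bear on it are the two earlier swaps at the same carbon, from trifluoromethyl to 2,6-dichloropyridin-4-yl and from tert-butyl to 2,6-dichloropyridin-4-yl, both of them within the scatter. Groups of quite different size and make-up at this carbon have therefore left this assay unmoved so far. No step beyond the scatter is expected for the move to quinolin-3-yl either, in either direction.

Compound 4 is expected to give 2000 nM in this assay, with a range of 700 nM to 6000 nM. Compound 4 is thus expected to show a step of no change at the digits printed from compound 3 to compound 4 (within the scatter).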

Compound 4, half-maximal inhibitory concentration: 6000 nM
Compound 4: middle estimate off by 3.0-fold (0.48 log units), on the low side, within the range that was stated.
By their numbers in this assay, from the lowest: compounds 1, 2 and 3 (each within the scatter of the next); then compound 4.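

In this assay the carbon between two ring nitrogen atoms proves less tolerant than compounds 1, 2 and 3 suggested, since quinolin-3-yl in place of 2,6-dichloropyridin-4-yl gives a 3.0-fold higher number from compound 3 to compound 4 (0.48 log units; beyond the scatter) in the weaker direction. Measured against the two smaller groups, the shift is larger, with a 6.0-fold higher number from compound 2 to compound 4 (0.78 log units; beyond the scatter) for the change from tert-butyl and a 6.0-fold higher number from compound 1 to compound 4 (0.78 log units; beyond the scatter) for the change from trifluoromethyl, so this position can respond to its substituent, and so far only in the direction of a weaker inhibitor. The data shown offer no measurement that accounts for this shift.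

The change from 2,6-dichloropyridin-4-yl to quinolin-3-yl adds a six-membered aromatic ring of carbon only and removes both chlorine atoms at once, so the compounds shown cannot assign the shift to either difference. Plain phenyl or pyridin-3-yl at this carbon would help to separate the two, while a small amine or a carboxylic acid there would test whether any group at this carbon gives a number lower than those of compounds 1, 2 and 3.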